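The source may hold more compounds than are shown below. What is called first, only, known or untested is meant among the compounds shown, and "the series" means these compounds.

Two members of this series have been measured in an ADME assay on Vero cells (Chlorocebus sabaeus) for cytotoxicity, read by MTT assay, with a stated time of 72 h; a lower number here means that less compound is tolerated, a higher number that more compound is tolerated. Compound 1 `CSCC(=O)N1CCN(c2nc(=O)c3cc(C(F)(F)F)cc([N+](=O)[O-])c3s2)CC1` carries a methylsulfanyl on the saturated chain carbon bound to the carbonyl carbon, and in this assay compound 1 gives > 125000 nM, which is a limit of the assay rather than a number. Compound 2 `CC(C)CC(=O)N1CCN(c2nc(=O)c3cc(C(F)(F)F)cc([N+](=O)[O-])c3s2)CC1` has isopropyl at that position, and in this assay compound 2 also reaches only a limit, > 125000 nM. The step that the two limits leave unreadable from compound 1 to compound 2 therefore cannot be read, as the limit of > 125000 nM in this assay, at which 2 of the 2 values shown sit, states. Compound 2 stands, on the numbers shown, at that limit, with no numeric value of its own and no measured neighbour that supplies one.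

Compound 3 `CCCC(=O)N1CCN(c2nc(=O)c3cc(C(F)(F)F)cc([N+](=O)[O-])c3s2)CC1` differs from compound 2 by hydrogen in place of methyl on a saturated chain carbon bound to two saturated chain carbons. Within the data shown here, the only measured step, a step that the two limits leave unreadable from compound 1 to compound 2, touches the same chain, but its size is not readable, so neither direction nor magnitude can be drawn from it. The removal of one methyl in compound 3 is a small change, and the expected step that the limit leaves unreadable from compound 2 to compound 3 is none beyond the scatter. Compound 3 is estimated in this assay at 200000 nM, within 100000 nM to 500000 nM, and is most likely to be reported again as a limit.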

Compound 3, half-maximal cytotoxic concentration: > 125000 nM
Compound 3: no number, only a limit; the forecaster's own chance of this, stated with the estimate: 85%; the middle value does not contradict the limit.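

No new step can be read among compound 1, compound 2 and compound 3, because all three stop at the same assay limit: the limit of > 125000 nM in this assay, at which 3 of the 3 values shown sit.

The compounds shown leave open whether any of these changes on the chain alters the result in this assay at all, since none of the three has a numeric value.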